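A few compounds are considered here, and "the series" means these few. Any claim that something is new, unique, unknown or untested is made for them only; others in the source may bear on it.

In a functional assay on QGY-7703 cells (Homo sapiens) for cytotoxicity, read by MTT assay, with a stated time of 24 h (on this read-out lower numbers stand for stronger inhibition and higher numbers for weaker inhibition), compound 3 `O=C1/C(=C/c2cccnc2)CN(S(=O)(=O)c2ccccc2)C/C1=C\c1ccccc1C(F)(F)F` gives 6240 nM and compound 1 `O=C1/C(=C/c2cccnc2)CN(S(=O)(=O)c2ccccc2)C/C1=C\c1ccccc1F` gives 4800 nM. Exchanging fluoro for trifluoromethyl on an aromatic carbon gives a 1.3-fold higher number from compound 1 to compound 3 (0.11 log units; within the scatter), so compound 3 stands level with compound 1. Compound 2 `O=C1/C(=C/c2ccncc2)CNC/C1=C\c1ccccc1F` shows a higher number, 14200 nM.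

Compound 4 `N#Cc1ccc(S(=O)(=O)N2C/C(=C\c3cccnc3)C(=O)/C(=C/c3ccccc3C(F)(F)F)C2)cc1` has cyano in place of hydrogen on an aromatic carbon, para to a large group, turning phenylsulfonyl to (4-cyanophenyl)sulfonyl (cyano in place of hydrogen on an aromatic carbon). Among the measured compounds shown here, the only measured single-place step, a 1.3-fold higher number from compound 1 to compound 3 (0.11 log units; within the scatter), lies elsewhere in the molecule, so it offers weak guidance and no step beyond the scatter is expected in this assay. The expected change is a 1.1-fold lower number from compound 3 to compound 4 (0.05 log units; within the scatter). For compound 4 the estimate is 5500 nM, with an expected range of 2500 nM to 12000 nM.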

Compound 4, half-maximal inhibitory concentration: 6150 nM
Compound 4: middle estimate off by 1.1-fold (0.05 log units), on the low side; low and high end bracket the measured number.
By their numbers in this assay, from the lowest: compounds 1, 4 and 3 (each within the scatter of the next); then compound 2.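

In this assay, cyano in place of hydrogen on an aromatic carbon, para to a large group, gives a 1.0-fold lower number from compound 3 to compound 4 (0.01 log units; within the scatter). This is the first single-place change shown on the sulfonyl-bound phenyl, and phenylsulfonyl to (4-cyanophenyl)sulfonyl leaves the number within the scatter, so no effect of cyano at this position can be read. Nothing at hand explains this result.

Going by these compounds, whether an amine or a carboxylic acid at this position would also leave the number within the scatter remains open. Also open, on these data alone, is whether cyano here would read the same alongside the fluoro group of compound 1.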